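Hydroxy to methyl on the sulfonyl aryl ring

This account rests on a few compounds, and the source may have more. Where it says the series, first, only, none or still open, it means among the compounds named here.

Among the measured compounds shown here, compound 2 `O=S(=O)(Nc1ccc2oc(-c3ccccc3)nc2c1)c1ccccc1O` and compound 1 `O=S(=O)(Nc1ccc(-c2nc3ccccc3o2)cc1)c1ccc(F)c(C(F)(F)F)c1` are the two measured members of the set. In an ADME assay on HEK293 cells (Homo sapiens) for cytotoxicity, read by resazurin assay, with a stated time of 48 h (a lower number here means that less compound is tolerated, a higher number that more compound is tolerated), compound 1 gives 82000 nM, while compound 2 gives 33000 nM, the lowest of the two numbers, with compound 1 standing a step above it that lies beyond the scatter. For the measured compounds named here, no step between measured compounds that differ in one place is available, so the pair is read only by its two values.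

Compound 3 `Cc1ccccc1S(=O)(=O)Nc1ccc2oc(-c3ccccc3)nc2c1` is not yet measured. It differs from compound 2 as follows: methyl in place of hydroxy on an aromatic carbon. The change sits on an aromatic carbon of a six-membered aromatic ring of carbon only, ortho to a large group; cut one bond further out it reads 2-hydroxyphenyl to 2-methylphenyl.

The measured pair does not bear on this change: compound 1 and compound 2 differ at several places at once. In this assay the expected step from compound 2 to compound 3 is a 1.1-fold lower number from compound 2 to compound 3 (0.04 log units; within the scatter), none beyond the scatter in either direction. Compound 3 is accordingly estimated at 30000 nM in this assay, within 12000 nM to 80000 nM.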

Compound 3, half-maximal cytotoxic concentration: 57000 nM
The estimate for compound 3 lay 1.9-fold (0.28 log units) below the measured number; measured number inside the range.
By their numbers in this assay, from the lowest: compounds 2, 3 and 1 (each within the scatter of the next, the first and the last beyond it).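

The change from 2-hydroxyphenyl to 2-methylphenyl gives the series its first comparison in one place, and in this assay it amounts to a small step (a 1.7-fold higher number from compound 2 to compound 3 (0.24 log units; within the scatter)). At this place, on an aromatic carbon ortho to a large group, the hydroxy group with its hydrogen-bond donor and acceptor can therefore give way to methyl without a step that stands clear of the scatter. This one pair offers no explanation for the reading, and nothing shown supplies one.

As far as these compounds go, whether other groups at this place would also stay within the scatter remains open: an amine, a carboxylic acid or a methoxy group would each test that, as would a longer chain in place of the methyl. Among the compounds shown here, also open is whether the same change from hydroxy to methyl reads alike on the core of compound 1, since the sulfonyl aryl ring of that compound carries different groups and no single-place step links it to compound 2 or compound 3.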